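The source may hold more compounds than are shown below. What is called first, only, known or untested is meant among the compounds shown, and "the series" means these compounds.

Compound 1 `CN(C)c1nonc1/C(=N/O)Nc1ccc(F)c(Br)c1`: > 36.6 mL/min/kg, a limit
Compound 2 `O/N=C(\Nc1ccc(F)c(Br)c1)c1nonc1NCc1ccccc1`: 35 mL/min/kg
Compound 3 `COCCNc1nonc1/C(=N/O)Nc1ccc(F)c(Br)c1`: > 36.6 mL/min/kg, a limit

Compound 2 alone has a true number in an ADME assay on liver (Rattus norvegicus) for metabolic stability, read by LC-MS, using S9 fraction, with a stated time of 30 min, tested at 5 uM, in the presence of a further agent that is not named here; on this read-out higher numbers stand for fast clearance and lower numbers for slow clearance. The other two compounds stand at the limit of > 36.6 mL/min/kg in this assay, at which 2 of the 3 values shown sit.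

Compound 4 `NCCNc1nonc1/C(=N/O)Nc1ccc(F)c(Br)c1` is reached from compound 2 by aminomethyl in place of phenyl on a saturated chain carbon bound to a nitrogen on an aromatic ring.

The closest measured change puts methoxymethyl in that same place, and it gives an at least 1.0-fold higher number from compound 2 to compound 3 (0.01 log units; that floor lies within the scatter). The other readable step, an at least 1.0-fold lower number from compound 1 to compound 2 (0.01 log units; that floor lies within the scatter), is equally small. Neither shows a step beyond the scatter, so none is expected here either, and the expected step is a 1.1-fold higher number from compound 2 to compound 4 (0.04 log units; within the scatter). For compound 4 the estimate is 38 mL/min/kg, with an expected range of 26 mL/min/kg to 55 mL/min/kg.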

Compound 4, clearance: 18.3 mL/min/kg
Compound 4: the middle estimate sits 2.1-fold (0.32 log units) above what was measured; the measured number lies below the stated range.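

In this assay, aminomethyl in place of phenyl gives a 1.9-fold lower number from compound 2 to compound 4 (0.28 log units; within the scatter), so this chain position still returns a true number without an aromatic ring. Amino in place of methoxy gives an at least 2.0-fold lower number from compound 3 to compound 4 (0.30 log units; that floor lies within the scatter), and (2-aminoethyl)amino in place of dimethylamino gives an at least 2.0-fold lower number from compound 1 to compound 4 (0.30 log units; that floor lies within the scatter). Both steps are floors only, since compound 1 and compound 3 each stand at a limit, yet they show that an amino end on this chain leaves the limit where a methoxy end does not. As far as these compounds go, whether a longer chain carrying the amine, or a carboxylic acid at the chain end, would stay with compound 4 or return to the limit remains open.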